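A few compounds are considered here, and "the series" means these few. Any claim that something is new, unique, unknown or untested is made for them only; others in the source may bear on it.

Measured so far in the cytotoxicity screen:

compound 1 `Nc1ccccc1NC(=O)c1ccc(NC(=S)NCc2cncc(Br)c2)cc1` — 9200 nM
compound 2 `Nc1ccccc1NC(=O)c1ccc(NC(=O)NCc2ccc(Cl)nc2)cc1` — 5200 nM
compound 3 `Nc1ccc(CNC(=O)Nc2ccc(C(=O)Nc3ccccc3N)cc2)cn1` — 7300 nM

Three compounds on a shared core have been run in a functional assay on HCT-116 cells (Homo sapiens) for cytotoxicity, read by MTT assay, with a stated time of 72 h; on this read-out lower numbers stand for stronger inhibition and higher numbers for weaker inhibition. Compound 1 gives the highest of the three numbers, but its distance to compound 3 and its distance to compound 2 both fall within the scatter of repeated measurements, so no ordering among the three can be claimed. Among the measured compounds shown here, the only single-point step among the measured compounds is a 1.4-fold higher number from compound 2 to compound 3 (0.15 log units; within the scatter), an amino in place of chloro on an aromatic carbon, and it stays within the scatter.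

For the measured compounds named here, compound 4 `Nc1ccccc1NC(=O)c1ccc(NC(=S)NCc2cccnc2)cc1` has not yet been measured. hydrogen in place of bromo on an aromatic carbon No measured pair exchanges a halogen for hydrogen on the same ring, so the only comparison at hand is the chloro-to-amino step between compound 2 and compound 3, which moved little. On that basis a 1.2-fold lower number from compound 1 to compound 4 (0.06 log units; within the scatter) is expected to stay within the scatter, with no clear direction. Compound 4 is therefore estimated at 8000 nM in this assay, with a range from 3500 nM to 20000 nM.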

Compound 4, half-maximal inhibitory concentration: 1000 nM
For compound 4 the middle estimate is 8.0-fold (0.90 log units) above the measured one; measured number below the stated range.
By their numbers in this assay, from the lowest: compound 4; then compounds 2, 3 and 1 (each within the scatter of the next).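

In this assay, hydrogen in place of bromo on this aromatic carbon, two atoms from the ring nitrogen, gives a 9.2-fold lower number from compound 1 to compound 4 (0.96 log units; beyond the scatter), the first step among these compounds to lie beyond the scatter. Among the compounds shown here, the only earlier step, a 1.4-fold higher number from compound 2 to compound 3 (0.15 log units; within the scatter), stayed within the scatter, so it gave no sign that a single change on this ring could move the number; the step from the 5-bromopyridin-3-yl group to the pyridin-3-yl group now shows that, in this compound pair, the carbon bearing the bromo is a place where one substitution matters. No supporting evidence is available to explain the size of this step.

The compounds shown leave open whether a fluoro, methyl or methoxy group on the same carbon would give a number closer to that of compound 1 or to that of compound 4, and so whether the step is specific to bromo. They also leave open whether hydrogen in place of a halogen would produce a step of similar size in compounds carrying the carbonyl of compound 2 rather than the thiocarbonyl of compound 1.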